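Dropping one trifluoromethyl from a diaryl urea

The source may report more compounds than this note shows. Statements on the series, on what has been measured and on what is new or still open speak of the compounds shown alone.

Of the compounds shown here, two have been measured in a functional assay on SF-268 cells (Homo sapiens) for inhibition, read by sulforhodamine B assay, with a stated time of 48 h, tested at 100 uM; a higher number here means a weaker effect of the compound at the concentration tested, a lower number a stronger effect. Compound 1 `O=C(Nc1cccc(-n2cc(-c3ccncc3)c(-c3cc(O)cc(Cl)c3)n2)c1)Nc1ccc(Cl)c(C(F)(F)F)c1` gives -27%. Compound 2 `COc1cc(Cl)cc(-c2nn(-c3cccc(NC(=O)Nc4cc(C(F)(F)F)cc(C(F)(F)F)c4)c3)cc2-c2ccncc2)c1` gives -88%, the lowest of the two numbers, and its gap to compound 1 lies beyond the usual scatter of this kind of measurement. Compound 3 `COc1cc(Cl)cc(-c2nn(-c3cccc(NC(=O)Nc4cccc(C(F)(F)F)c4)c3)cc2-c2ccncc2)c1` is not yet measured; it differs from compound 2 in one place only: hydrogen in place of trifluoromethyl on an aromatic carbon. Going by the values given here, no measured pair shows this exact change, so its effect is not known from the data. A weakening is expected, because compound 1, which also carries a single trifluoromethyl on that ring, gives -27% in this assay , though it differs in further places as well. The step from compound 2 to compound 3 is estimated as a number 33 percentage points higher from compound 2 to compound 3 (beyond the scatter), in the direction of a weaker effect and probably beyond the scatter. Compound 3 is therefore expected to give about -55%, within a range from -90% to -10%.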

Compound 3, a percentage reported as activity, at one concentration (the size of the read-out at that concentration, not a potency): -28%
Compound 3: middle estimate off by 27 percentage points, on the low side, and the stated range covers the measured number.
By their numbers in this assay, from the lowest: compound 2; then compounds 3 and 1 (each within the scatter of the next).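

In this assay, hydrogen in place of trifluoromethyl on an aromatic carbon gives a number 60 percentage points higher from compound 2 to compound 3 (beyond the scatter), so this one swap alone produces a large weakening of the effect. The earlier compounds shown here differed from each other in more than one place, whereas this pair ties the loss to this single position, even with the other trifluoromethyl group on the ring still present. No measurement is available that explains why this change matters so much.

The compounds shown leave open whether a different group at this position, such as a nitrile or an amine, would retain the stronger effect of compound 2 or match the weaker one of compound 3. They also leave open whether the same swap would have a similar effect with other groups elsewhere on the shared core.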